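A trifluoromethyl group added to compound 1

The source may hold more compounds than are shown below. What is called first, only, known or untested is meant among the compounds shown, and "the series" means these compounds.

In a functional assay on the whole organism for inhibition, with Scenedesmus acutus as the target, with a stated time of 20 min (on this read-out higher numbers stand for weaker inhibition and lower numbers for stronger inhibition), compound 1 (`O=c1c2c(sn1-c1ccc(Cl)cc1)CCCC2`) gives 20400 nM and compound 2 (`O=c1c2c(sn1-c1ccc([N+](=O)[O-])cc1)CCCC2`) gives 23400 nM in the same test. These two numbers lie within the usual scatter of each other, so compound 1 holds no clear rank. Compound 3 (`O=c1c2c(sn1-c1ccc(Cl)cc1C(F)(F)F)CCCC2`) has not yet been measured. It carries trifluoromethyl in place of hydrogen on an aromatic carbon, ortho to a large group and meta to a chloro group. Among the compounds with values here, the only measured step, a 1.1-fold higher number from compound 1 to compound 2 (0.06 log units; within the scatter) for nitro in place of chloro, stayed within the scatter. It concerns a different place and a different exchange, so it offers only weak guidance. No shift beyond the scatter is therefore expected in this assay and the estimated step is a 1.0-fold lower number from compound 1 to compound 3 (0.01 log units; within the scatter) with wide uncertainty. For compound 3 the expected value is 20000 nM with an estimated range from 6000 nM to 60000 nM in this test.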

Compound 3, half-maximal inhibitory concentration: 55000 nM
For compound 3 the middle estimate is 2.8-fold (0.44 log units) below the measured one; measured number inside the range.
By their numbers in this assay, from the lowest: compounds 1 and 2 (each within the scatter of the next); then compound 3.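

Putting trifluoromethyl in place of hydrogen on this aromatic carbon, ortho to a large group and meta to a chloro group, gives a 2.7-fold higher number from compound 1 to compound 3 (0.43 log units; beyond the scatter) in this assay. This is the first step among these compounds to lie beyond the scatter, and since higher numbers stand for weaker inhibition, it shows that this position is sensitive to change and that this particular addition goes with weaker inhibition, though the step is modest. Nothing available here accounts for the shift.

From the compounds shown here alone, whether the shift belongs to trifluoromethyl itself or would follow any group on this carbon remains open; a methyl group or an amine in the same place would help to tell these apart. Going by these compounds, it is also open whether the same addition would act alike with nitro in place of chloro.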